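Pyrrolidine amides: swapping the biaryl tail for cyclohexyloxy

The source may hold more compounds than are shown below. What is called first, only, known or untested is meant among the compounds shown, and "the series" means these compounds.

Compound 3 `O=C(CCc1ccc(-c2cccc(Cl)c2)cc1)N1CCCC1` gives 25400 nM in an assay on HEK293 cells for inhibition of N-acylethanolamine-hydrolyzing acid amidase (Rattus norvegicus), read by LC-MS, with a stated time of 30 min (a lower number here means a stronger inhibitor, a higher number a weaker inhibitor), and stands highest of the two numbers in hand; nearest is compound 1 `O=C(CCc1ccc(-c2ccc(F)cc2)cc1)N1CCCC1` with 3400 nM, a gap of a 7.5-fold higher number from compound 1 to compound 3 (0.87 log units; beyond the scatter). Compound 2 `O=C(CCc1ccc(-c2ccccc2Cl)cc1)N1CCCC1` returns only the limit > 100000 nM, as noted in the limit of > 100000 nM in this assay, at which 1 of the 3 values shown sits. The step to compound 4 `O=C(CCc1ccc(OC2CCCCC2)cc1)N1CCCC1` is cyclohexyloxy in place of 3-chlorophenyl on an aromatic carbon. Going by the values given here, no measured step bears directly on this change: an at least 29-fold higher number from compound 1 to compound 2 (1.46 log units; beyond the scatter) and an at least 3.9-fold lower number from compound 2 to compound 3 (0.59 log units; beyond the scatter) concern chlorine placement on the distal aromatic ring, showing that the tail strongly governs this assay, but they do not speak to replacing the ring by cyclohexyloxy. Expectation therefore rests on the wide spread already seen; compound 4 is estimated at 5000 nM, between 800 nM and 40000 nM, an expected 5.1-fold lower number from compound 3 to compound 4 (0.71 log units; beyond the scatter).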

Compound 4, half-maximal inhibitory concentration: 700 nM
Estimate against measurement, compound 4: 7.1-fold (0.85 log units) above, and the stated range ends above it.
By their numbers in this assay, from the lowest: compound 4; then compound 1; then compound 3. At a limit, above all of these: compound 2.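

The aromatic distal ring is not required at this position: in (this assay) the non-aromatic cyclohexyloxy group reads better than the aryl tails of compound 3 and compound 1, with (a 36-fold lower number from compound 3 to compound 4 (1.56 log units; beyond the scatter)) and (a 4.9-fold lower number from compound 1 to compound 4 (0.69 log units; beyond the scatter)). Compound 2 stays at a limit, so its step is a bound, (an at least 140-fold lower number from compound 2 to compound 4 (2.15 log units; beyond the scatter)): (the limit of > 100000 nM in this assay, at which 1 of the 4 values shown sits).

The oxygen and the non-aromatic ring enter together, and the compounds shown do not separate their contributions. Also open, as far as these compounds go, is how an amine on the cyclohexyl ring, or a longer alkoxy chain in place of cyclohexyloxy, would read.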